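The compounds below may be only part of what the source reports. "The series", "measured", "known", "first", "only" and "open" are said of these compounds alone.

Series notes, shared core with a different group in each compound. In a toxicity assay on L02 cells (Homo sapiens) for cytotoxicity, read by MTT assay, with a stated time of 72 h (a lower number here means a stronger inhibitor, a higher number a weaker inhibitor), compound 2 `O=C1c2c[n+]([O-])c3ccccc3c2C(=O)c2c1c1ccccc1n2Cc1cn([C@@H]2C[C@H](O)[C@@H](CO)O2)nn1` gives 630 nM and stands in the middle of the three measured numbers. The lowest number on this scale is that of compound 1 `O=C1c2c[n+]([O-])c3ccccc3c2C(=O)c2c1c1ccccc1n2CCCCn1ccnc1` at 150 nM, and the highest is that of compound 3 `CCCCN1CCN(CCCCn2c3c(c4ccccc42)C(=O)c2c[n+]([O-])c4ccccc4c2C3=O)CC1` at 5690 nM; both gaps lie beyond the scatter.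

The change to compound 4 `CC1(C)O[C@@H](CO)[C@H](Cn2cc(Cn3c4c(c5ccccc53)C(=O)c3c[n+]([O-])c5ccccc5c3C4=O)nn2)O1` is (5-(hydroxymethyl)-2,2-dimethyl-1,3-dioxolan-4-yl)methyl in place of 4-hydroxy-5-(hydroxymethyl)oxolan-2-yl on an aromatic nitrogen and it sits on an aromatic nitrogen of a five-membered aromatic ring with 3 nitrogen.

For the measured compounds named here, only one measured step bears on this, and only loosely. The step of a 38-fold higher number from compound 1 to compound 3 (1.58 log units; beyond the scatter) is large and beyond the scatter, but it exchanges different groups, on a saturated chain carbon, four bonds along the chain from an aromatic nitrogen. Going by the values given here, no measured step touches the 4-hydroxy-5-(hydroxymethyl)oxolan-2-yl group of compound 2. That large step shows that a change of group on the shared core can move the number a long way, but it gives no direction here, so the range is kept wide.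

The estimated change is a 1.1-fold higher number from compound 2 to compound 4 (0.05 log units; within the scatter) and no shift beyond the scatter is therefore expected in this assay as the central case. For compound 4 the estimated value is 700 nM with an expected range from 200 nM to 2500 nM in this read-out.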

Compound 4, half-maximal inhibitory concentration: 500 nM
Beside the measured number, compound 4's estimate is 1.4-fold (0.15 log units) above it; the range from low to high includes it.
By their numbers in this assay, from the lowest: compound 1; then compounds 4 and 2 (each within the scatter of the next); then compound 3.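

In this assay, the place on an aromatic nitrogen of the five-membered aromatic ring with 3 nitrogen now has its own measured step: (5-(hydroxymethyl)-2,2-dimethyl-1,3-dioxolan-4-yl)methyl in place of 4-hydroxy-5-(hydroxymethyl)oxolan-2-yl gives a 1.3-fold lower number from compound 2 to compound 4 (0.10 log units; within the scatter) and so leaves the two compounds unseparated. The two groups differ in heavy atoms, ring hetero atoms, hydrogen-bond donors and defined stereocentres, yet this exchange does not show the kind of shift seen on the saturated chain in a 38-fold higher number from compound 1 to compound 3 (1.58 log units; beyond the scatter), although that step concerns other groups at another place. Nothing measured here accounts for this result.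

The two oxygen-bearing ring groups compared at this place are close relatives, so one step within the scatter does not show how far the position tolerates change. A plain butyl chain, or a group carrying an amine or a carboxylic acid on the same aromatic nitrogen, would test whether the number at this place can move beyond the scatter, and in which direction.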